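The source may hold more compounds than are shown below. What is called first, only, known or untested is meant among the compounds shown, and "the series" means these compounds.

Of the compounds shown here, two have been tested so far in a functional assay on Raji cells (Homo sapiens) for cytotoxicity, with a stated time of 72 h; a lower number here means that less compound is needed, a higher number that more compound is needed for the effect: compound 1, `C=C[C@@](C)(/C=C/c1ccc(O)c(C=O)c1)CCC=C(C)C`, and compound 2, `C=C[C@@](C)(/C=C/c1ccc(O)c(/C=C/C(=O)OCC)c1)CCC=C(C)C`. Compound 1 gives > 26000 nM, which is a limit of the assay and not a number. Compound 2 gives > 26000 nM, which is likewise a limit. Compound 2 therefore has no exact place on the scale, and the whole record so far is the limit of > 26000 nM in this assay, at which 2 of the 2 values shown sit.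

Compound 3, `C=C[C@@](C)(/C=C/c1ccc(O)c(/C=C/c2ccc(Cl)c(Cl)c2)c1)CCC=C(C)C`, keeps the shared core and changes one group: 3,4-dichlorophenyl in place of ethoxycarbonyl on a double-bonded chain carbon bound to a double-bonded chain carbon. In words, this places 3,4-dichlorophenyl in place of ethoxycarbonyl on a double-bonded chain carbon bound to a double-bonded chain carbon.

Within the data shown here, only one measured step bears on this change, since it altered the same side chain: a step that the two limits leave unreadable from compound 1 to compound 2. It offers no size to carry forward, so any forecast is loose. A modest move towards lower numbers in this assay is expected, and another result at the limit remains quite possible. The expected size is an at least 1.4-fold lower number from compound 2 to compound 3 (0.15 log units; that floor lies within the scatter). For compound 3 the estimated value is 18000 nM, with an expected range from 5000 nM to 40000 nM.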

Compound 3, half-maximal effective concentration: > 26000 nM
Compound 3 ended at the assay's limit (the forecaster's own chance of this, stated with the estimate: 55%); middle value at least 1.4-fold (0.15 log units) away from the limit.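

In this assay compound 3 gives > 26000 nM, which is a limit of the assay and not a number. Compound 2 also sits at a limit, so the change from compound 2 to compound 3 cannot be read as a step, and the record stands thus: the limit of > 26000 nM in this assay, at which 3 of the 3 values shown sit.

The compounds shown leave open whether any group on this side chain can give a true number in this assay.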